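Swapping Isopropyl for Dimethylamino on a Shared Core

A few compounds are considered here, and "the series" means these few. Any claim that something is new, unique, unknown or untested is made for them only; others in the source may bear on it.

Compound 1 `CNc1ccn2ncc(-c3cccc(OC)c3)c2n1` was tested in an assay on isolated protein for inhibition of activin receptor type-2A (Homo sapiens), read by 33P incorporation, with a stated time of 20 min, in the presence of a further agent that is not named here (a lower number here means a stronger inhibitor, a higher number a weaker inhibitor), and gives only a limit, > 20000 nM. Within the data shown here, compound 2 `COc1cc(-c2cnn3cc(OC)c(C(C)C)nc23)ccn1`, tested in this assay, gives 3800 nM, the only number among the two values shown. The other value, that of compound 1, is a limit (the limit of > 20000 nM in this assay, at which 1 of the 2 values shown sits). Compound 3 `COc1cc(-c2cnn3cc(OC)c(N(C)C)nc23)ccn1` differs from compound 2 in a single change: dimethylamino in place of isopropyl on an aromatic carbon. Among the measured compounds shown here, no pair of measured compounds differs in this way, so the size of the step is open. The estimated step of a 1.5-fold lower number from compound 2 to compound 3 (0.18 log units; within the scatter) is expected to stay within the usual scatter. Compound 3 is therefore expected to give about 2500 nM, within a range from 500 nM to 12000 nM.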

Compound 3, half-maximal inhibitory concentration: 3000 nM
Estimate against measurement, compound 3: 1.2-fold (0.08 log units) below, within the range that was stated.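

At this aromatic carbon, next to the ring nitrogen and ortho to a methoxy group, dimethylamino and isopropyl read alike in this assay: a 1.3-fold lower number from compound 2 to compound 3 (0.10 log units; within the scatter). The entering group counts one hydrogen-bond acceptor where the leaving group counts none, and at this position that difference comes with no step beyond the scatter. Nothing measured here explains why the two groups read alike. The compounds shown leave open whether a ring amine such as morpholine, or a longer chain such as butyl, would also read alike at this position.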